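The source may hold more compounds than are shown below. What is called first, only, known or untested is meant among the compounds shown, and "the series" means these compounds.

In a functional assay on HOP-62 cells (Homo sapiens) for cytotoxicity, read by resazurin assay, with a stated time of 72 h (a lower number here means a stronger inhibitor, a higher number a weaker inhibitor), compound 1 (`COc1cc(/C=C/C(=O)OCCCO[N+](=O)[O-])ccc1OCCCO[N+](=O)[O-]`) reads > 50000 nM as a limit of the assay, not a number. For the measured compounds named here, compound 2 (`COc1cc(/C=C/C(=O)OCCCCCO[N+](=O)[O-])ccc1O`) gives 12500 nM as the only number so far. Compound 3 (`COc1cc(/C=C/C(=O)OCCCO[N+](=O)[O-])ccc1O`) differs from compound 2 by nitrooxy in place of 2-(nitrooxy)ethyl on a saturated chain carbon, three bonds along the chain from an oxygen next to a carbonyl group. Going by the values given here, no step between measured compounds sizes this change. A modest loss of potency in this assay is expected (a 1.6-fold higher number from compound 2 to compound 3 (0.20 log units; within the scatter)). The estimated value for compound 3 is 20000 nM with an expected range (8000 nM to 50000 nM).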

Compound 3, half-maximal inhibitory concentration: 19400 nM
For compound 3 the middle estimate is 1.0-fold (0.01 log units) above the measured one; low and high end bracket the measured number.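

In this assay, nitrooxy in place of 2-(nitrooxy)ethyl on a saturated chain carbon gives a 1.6-fold higher number from compound 2 to compound 3 (0.19 log units; within the scatter), so this pair resolves no effect of the change. Hydrogen in place of 3-(nitrooxy)propyl on an oxygen on an aromatic ring gives an at least 2.5-fold lower number from compound 1 to compound 3 (0.41 log units; beyond the scatter), the first step here that is sized beyond the scatter. That step rests on a limit of the assay for compound 1, not a number: the limit of > 50000 nM in this assay, at which 1 of the 3 values shown sits.

As far as these compounds go, its full size remains open. So does the effect in this assay of a longer chain, or of an amine or a carboxylic acid in place of nitrooxy.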